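A few compounds are considered here, and "the series" means these few. Any claim that something is new, unique, unknown or untested is made for them only; others in the source may bear on it.

Three related compounds have been tested in a functional assay on SMMC-7721 cells (Homo sapiens) for cytotoxicity, read by MTT assay, with a stated time of 24 h; a lower number here means a stronger inhibitor, a higher number a weaker inhibitor. Compound 1, `Cc1ccc(S(=O)(=O)N2C/C(=C\c3ccccc3F)C(=O)/C(=C/c3ccccc3F)C2)cc1`, gives 4100 nM in this assay. Compound 2, `O=C1/C(=C/c2ccccc2F)CN(S(=O)(=O)c2ccc(O[N+](=O)[O-])cc2)C/C1=C\c1ccccc1F`, gives 6200 nM in this assay. Compound 3, `Cc1ccc(S(=O)(=O)N2C/C(=C\c3cccc(F)c3)C(=O)/C(=C/c3cccc(F)c3)C2)cc1`, gives 18100 nM in this assay, the highest of the three numbers, and its distance from compound 1 and from compound 2 lies beyond the usual scatter of this kind of measurement.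

Compound 1 and compound 2 share a core, and compound 3 rests on a core built from the same atoms joined differently; the difference between the two cores is not broken down here. Within the first core, the change from compound 1 to compound 2 is nitrooxy in place of methyl on an aromatic carbon, and its outcome was a 1.5-fold higher number from compound 1 to compound 2 (0.18 log units; within the scatter), a step that does not stand apart from the scatter.

Compound 4, `O=C1/C(=C/c2cccc(F)c2)CN(S(=O)(=O)c2ccc(O[N+](=O)[O-])cc2)C/C1=C\c1cccc(F)c1`, has not yet been measured in this assay. Among the compounds with values here, it differs from compound 3 by nitrooxy in place of methyl on an aromatic carbon, which is the same change as the one made from compound 1 to compound 2, in the same place. On the grounds that compound 1 moved to compound 2 by a 1.5-fold higher number from compound 1 to compound 2 (0.18 log units; within the scatter), the step from compound 3 to compound 4 is expected to be of a similar size, estimated here as a 1.3-fold higher number from compound 3 to compound 4 (0.12 log units; within the scatter). For compound 4 the estimated value in this assay is therefore 24000 nM, with an expected range from 10000 nM to 55000 nM.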

Compound 4, half-maximal inhibitory concentration: 15300 nM
Beside the measured number, compound 4's estimate is 1.6-fold (0.20 log units) above it, and the stated range covers the measured number.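

In this assay, within the data shown here, putting nitrooxy in place of methyl on the aromatic carbon of the 4-methylphenyl group gives a 1.2-fold lower number from compound 3 to compound 4 (0.07 log units; within the scatter), so on this second core the change again produces no step that stands apart from the scatter. Set side by side, the two steps show that the change carries over from one core to the other with no difference that this measurement can detect: the same change on two cores in this assay, a 1.5-fold higher number (0.18 log units; within the scatter) from compound 1 to compound 2 and a 1.2-fold lower number (0.07 log units; within the scatter) from compound 3 to compound 4, 1.8-fold (0.25 log units) apart, within the scatter of two such steps. This shows only that, for these two pairs of compounds, swapping a single methyl for the larger nitrooxy group leaves the cytotoxicity read-out within the noise on both cores; it does not show that the change has no effect at all, since a small effect could lie hidden in the scatter, and two pairs in one cell line cannot establish a rule for the whole series.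

The compounds shown leave open whether an amine or a carboxylic acid on the same aromatic carbon would also leave the number within the scatter. They also leave open whether the nitrooxy change would behave this way on a core carrying chlorine in place of fluorine on its two outer aromatic rings.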